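Fluoro for bromo on the carbonyl-bearing aryl ring

A few compounds are considered here, and "the series" means these few. Any claim that something is new, unique, unknown or untested is made for them only; others in the source may bear on it.

Measured compounds:
compound 1 `COc1cc(-c2nnc3n2NC(c2cccs2)C(C(=O)c2ccc(F)cc2)S3)cc(OC)c1OC` — 43700 nM
compound 2 `COc1cc(-c2nnc3n2NC(c2ccco2)C(C(=O)c2cccc(Br)c2)S3)cc(OC)c1OC` — 91800 nM
compound 3 `COc1cc(-c2nnc3n2NC(c2ccco2)C(C(=O)c2ccc(Br)cc2)S3)cc(OC)c1OC` — > 100000 nM

Three compounds sharing one core were tested in a functional assay on MCF7 cells (Homo sapiens) for cytotoxicity, read by MTT assay, with a stated time of 48 h; on this read-out lower numbers stand for stronger inhibition and higher numbers for weaker inhibition. Compound 1 gives 43700 nM, and compound 2 gives 91800 nM. For compound 3 the assay reports only a limit, > 100000 nM, so no number is known for it. Among the compounds with values here, the single measured step, an at least 1.0-fold higher number from compound 2 to compound 3 (0.03 log units; that floor lies within the scatter), lies within the scatter and adds nothing to what the limit shows; the evidence on it is the limit of > 100000 nM in this assay, at which 1 of the 3 values shown sits.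

Compound 4 `COc1cc(-c2nnc3n2NC(c2ccco2)C(C(=O)c2ccc(F)cc2)S3)cc(OC)c1OC` is the compound yet to be measured. It differs from compound 3 by fluoro in place of bromo on an aromatic carbon, read one bond further out as 4-bromophenyl to 4-fluorophenyl on the carbonyl. Within the data shown here, no measured step covers this exchange. Compound 1 carries the same 4-fluorophenyl carbonyl on a thiophene-bearing core and gives 43700 nM, a number rather than a limit. The expected step is therefore an at least 1.2-fold lower number from compound 3 to compound 4 (0.09 log units; that floor lies within the scatter), toward a number below the limit, though a limit remains possible. Compound 4 is estimated at 80000 nM, within 30000 nM to 250000 nM.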

Compound 4, half-maximal inhibitory concentration: > 100000 nM
Compound 4: only a limit was reported; the forecaster's own chance of this, stated with the estimate: 35%; at least 1.2-fold (0.09 log units) between middle value and limit.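

With 4-fluorophenyl in place of 4-bromophenyl on the carbonyl, no number emerges in this assay, and the step between the two limits cannot be read; compound 3 and compound 4 both remain limits: the limit of > 100000 nM in this assay, at which 2 of the 4 values shown sit. The exchange of 3-bromophenyl for 4-fluorophenyl gives an at least 1.0-fold higher number from compound 2 to compound 4 (0.03 log units; that floor lies within the scatter), so this comparison separates nothing. The clearer comparison lies at the saturated ring carbon rather than on the aryl ring: with the 4-fluorophenyl carbonyl unchanged, furan-2-yl in place of thiophen-2-yl gives an at least 2.2-fold higher number from compound 1 to compound 4 (0.35 log units; beyond the scatter).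

The compounds shown leave open where compound 3 and compound 4 would fall if either gave a number, and whether thiophen-2-yl would give a lower number with a 4-bromophenyl carbonyl as well. They also leave open how an amine or a carboxylic acid in place of the halogen would read in this assay.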